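Urea series on the shared core: aryl to cyclohexyl

A few compounds are considered here, and "the series" means these few. Any claim that something is new, unique, unknown or untested is made for them only; others in the source may bear on it.

Three compounds share the core of compound 1 `O=C(Nc1ccccc1)Nc1cccc(CNc2nccnc2Cl)c1` and differ only in the group on the amide-type nitrogen. In a functional assay on HepG2 cells (Homo sapiens) for antiproliferative activity, read by MTT assay, with a stated time of 48 h (a higher number here means a weaker inhibitor, a lower number a stronger inhibitor), compound 1 gives 15600 nM. Compound 2 `COc1ccc(NC(=O)Nc2cccc(CNc3nccnc3Cl)c2)cc1` gives 12000 nM in this assay, and compound 3 `Cc1ccc(NC(=O)Nc2cccc(CNc3nccnc3Cl)c2)c(C)c1` gives 9290 nM. Compound 2 stands second highest of the three numbers; its nearest neighbour is compound 3 and its furthest compound 1, and both gaps lie within the scatter. The steps of a 1.3-fold lower number from compound 1 to compound 2 (0.11 log units; within the scatter) and a 1.3-fold lower number from compound 2 to compound 3 (0.11 log units; within the scatter) show that methoxy and methyl groups on the phenyl move nothing beyond the scatter.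

Compound 4 `O=C(Nc1cccc(CNc2nccnc2Cl)c1)NC1CCCCC1` is not yet measured. The change is cyclohexyl in place of 4-methoxyphenyl on an amide-type nitrogen. The measured steps bear on it only loosely: they vary the substituents on an aromatic ring, whereas here the aromatic ring itself is exchanged for a non-aromatic one. Within the data shown here, no measured pair covers that exchange, so the expectation rests on the flatness seen so far: a step of a 1.1-fold higher number from compound 2 to compound 4 (0.03 log units; within the scatter) is expected, with a wide range. Compound 4 is thus estimated at 13000 nM, from 5000 nM to 35000 nM.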

Compound 4, half-maximal inhibitory concentration: > 40000 nM
Compound 4: only a limit was reported; the forecaster's own chance of this, stated with the estimate: 10%; middle value at least 3.0-fold (0.48 log units) away from the limit.
By their numbers in this assay, from the lowest: compounds 3, 2 and 1 (each within the scatter of the next). At a limit, above all of these: compound 4.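

In this assay, compound 4 is reported only as a limit of the assay, not as a number: the limit of > 40000 nM in this assay, at which 1 of the 4 values shown sits. The group on the amide-type nitrogen proved insensitive only while the aromatic ring stayed in place; exchanging that ring for cyclohexyl gives a change beyond the scatter in every comparison: an at least 3.3-fold higher number from compound 2 to compound 4 (0.52 log units; beyond the scatter), an at least 4.3-fold higher number from compound 3 to compound 4 (0.63 log units; beyond the scatter) and an at least 2.5-fold higher number from compound 1 to compound 4 (0.40 log units; beyond the scatter). Among the compounds shown, compound 1, compound 2 and compound 3, all carrying an aromatic ring there, lie within the scatter of one another, while compound 4, the only one with a non-aromatic ring, stands apart, a contrast that rests on this single compound.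

On these data alone, the true size of these steps remains open, as each has a bound on one side only. Also open, as far as these compounds go, is whether a pyridyl ring would match the aryl compounds, and whether a hexyl chain or a piperidine ring would match compound 4.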